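Swapping a Pyridine Acid for a Fluorinated Benzoic Acid

This account rests on a few compounds, and the source may have more. Where it says the series, first, only, none or still open, it means among the compounds named here.

Among the measured compounds shown here, compound 1 `Cc1c(OCCCCOc2cncc(C(=O)O)c2)ccc(C(=O)CC(C)(C)C)c1O` is one of two compounds measured in an assay for positive allosteric modulation of metabotropic glutamate receptor 3 (Rattus norvegicus) (a lower number here means that less compound is needed, a higher number that more compound is needed for the effect), and in it compound 1 gives 180 nM. The other, compound 2 `COc1cc(OCCCCOc2ccc(C(=O)CC(C)(C)C)c(O)c2C)cc(C(=O)O)c1`, carries a methoxy-substituted carboxyphenyl at the end of the same linker; in this assay compound 2 gives 703 nM. Compound 1 therefore stands at the lower of the two numbers, and its gap to compound 2 lies beyond the usual scatter.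

Compound 3 `Cc1c(OCCCCOc2ccc(C(=O)O)cc2F)ccc(C(=O)CC(C)(C)C)c1O` has not yet been measured. Compared with compound 1, the change is 4-carboxy-2-fluorophenyl in place of 5-carboxypyridin-3-yl on an oxygen on a saturated carbon. The shared core and the linker are unchanged; only the group carrying the carboxylic acid differs.

For the measured compounds named here, no step between measured compounds matches this change. The two measured values show that compound 2, with a carboxyphenyl group, gave a higher number than compound 1 with its carboxypyridinyl group, so a modest move toward a higher number in this assay is expected, possibly still within the scatter. The step from compound 1 to compound 3 is expected to be a 1.8-fold higher number from compound 1 to compound 3 (0.25 log units; within the scatter). Compound 3 is estimated at 320 nM, with a range from 110 nM to 950 nM.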

Compound 3, half-maximal effective concentration: 1230 nM
The estimate for compound 3 lay 3.8-fold (0.58 log units) below the measured number; the whole stated range lies below it.
By their numbers in this assay, from the lowest: compound 1; then compounds 2 and 3 (each within the scatter of the next).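

Putting 4-carboxy-2-fluorophenyl in place of 5-carboxypyridin-3-yl on an oxygen on a saturated carbon gives, in this assay, a 6.8-fold higher number from compound 1 to compound 3 (0.83 log units; beyond the scatter), so keeping a carboxylic acid at the end of the linker does not by itself keep the number low. Compound 3 lies within the scatter of compound 2, and both end in a six-membered aromatic ring of carbon only, whereas compound 1, the only one of the three with a nitrogen in that ring, has the lowest number; this holds for these three compounds alone, and none of them goes against it. Nothing measured here explains why the number rises with this change.

From the compounds shown here alone, this single step changes several things at once: the ring nitrogen leaves, a fluorine enters, and the carboxylic acid sits differently on the ring, so the share of each remains unknown. A 4-carboxyphenyl without the fluorine, or a 5-carboxypyridin-3-yl carrying a fluorine, would separate the ring nitrogen from the fluorine.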